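Working notes: from compound 1 to compound 4

The source may report more compounds than this note shows. Statements on the series, on what has been measured and on what is new or still open speak of the compounds shown alone.

- compound 1 `O=C(NNC(=O)c1ccc2[nH]c(-c3ccc([N+](=O)[O-])o3)nc2c1)c1ccccc1` gives 15.6 ug/mL
- compound 2 `COc1cc(C(=O)NNC(=O)c2ccc3[nH]c(-c4ccc([N+](=O)[O-])s4)nc3c2)cc(OC)c1OC` gives 31.3 ug/mL
- compound 3 `O=C(NNC(=O)c1cc2ccccc2cc1O)c1ccc2[nH]c(-c3ccc([N+](=O)[O-])s3)nc2c1` gives 31.3 ug/mL

In a functional assay on K562 cells (Homo sapiens) for inhibition, read by sulforhodamine B assay, with a stated time of 48 h (on this read-out lower numbers stand for stronger inhibition of growth and higher numbers for weaker inhibition of growth), compound 1 gives 15.6 ug/mL and stands within the scatter of both compound 2 and compound 3. Compound 4 `COc1ccc(C(=O)NNC(=O)c2ccc3[nH]c(-c4ccc([N+](=O)[O-])o4)nc3c2)cc1OC` carries 3,4-dimethoxyphenyl in place of phenyl on a carbonyl carbon, with the rest of compound 1 unchanged (3,4-dimethoxyphenyl in place of phenyl on a carbonyl carbon). Among the compounds with values here, no measured pair shows this change on its own, so no step beyond the scatter is expected in this assay in either direction. The estimated move a 1.3-fold higher number from compound 1 to compound 4 (0.11 log units; within the scatter) is expected to stay small. Compound 4 is estimated at 20 ug/mL with an expected range of 7.8 ug/mL to 62.5 ug/mL for now.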

Compound 4, concentration for 50% growth inhibition: 15.6 ug/mL
Compound 4: middle estimate off by 1.3-fold (0.11 log units), on the high side; measured number inside the range.
By their numbers in this assay, from the lowest: compounds 1, 4, 2 and 3 (each within the scatter of the next).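

In this assay, within the data shown here, there is no change at the digits printed from compound 1 to compound 4 (within the scatter) with 3,4-dimethoxyphenyl in place of phenyl on a carbonyl carbon, the first one-place comparison. At this position, a group with more heavy atoms and two hydrogen-bond acceptors is therefore accepted with no step beyond the scatter. No measurement available here gives a cause for this result.

From the compounds shown here alone, it remains open whether a carboxylic acid or an aminomethyl group on this phenyl would move the number beyond the scatter. A longer alkyl chain in place of the phenyl is equally unresolved.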